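Removing a methoxy from compound 3: working notes

The compounds below may be only part of what the source reports. "The series", "measured", "known", "first", "only" and "open" are said of these compounds alone.

- compound 1 `COc1ccc(C2OC(c3cc(OC)c(OC)c(OC)c3)=NN2C(C)=O)cc1OC(C)=O`: 10200 nM
- compound 2 `COc1ccc(C2=NN(C(C)=O)C(c3cc(OC)ccc3OC)O2)cc1`: 1300 nM
- compound 3 `COc1ccc(C2=NN(C(C)=O)C(c3cc(OC)c(OC)c(OC)c3)O2)cc1`: 500 nM

In a functional assay on A10 cells (Rattus norvegicus) for antiproliferative activity, read by immunofluorescence, with a stated time of 24 h (on this read-out higher numbers stand for an effect only at larger amounts of compound and lower numbers for an effect already at smaller amounts), compound 3 has the lowest number of the three, and the values of compound 1 and compound 2 both lie above it beyond the scatter. Compound 4 `COc1ccc(C2=NN(C(C)=O)C(c3cc(OC)cc(OC)c3)O2)cc1` has hydrogen in place of methoxy on an aromatic carbon of compound 3: hydrogen in place of methoxy on an aromatic carbon. Within the data shown here, no measured pair shows this change alone, so the expectation is uncertain. The nearest guide is compound 2 at 1300 nM, a higher number than that of compound 3. In this assay, a rise beyond the scatter is expected, with an estimated 3.0-fold higher number from compound 3 to compound 4 (0.48 log units; beyond the scatter). For compound 4 the estimated value is 1500 nM, with an expected range of 500 nM to 5000 nM.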

Compound 4, half-maximal effective concentration in the A10 assay: 1000 nM
Beside the measured number, compound 4's estimate is 1.5-fold (0.18 log units) above it; measured number inside the range.
By their numbers in the A10 assay, from the lowest: compounds 3, 4 and 2 (each within the scatter of the next, the first and the last beyond it); then compound 1.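

In the A10 assay, the methoxy on this aromatic carbon, para to a large group and ortho to two methoxy groups, now has a single-change comparison, which gives a 2.0-fold higher number from compound 3 to compound 4 (0.30 log units; within the scatter). On this read-out, hydrogen at this position is therefore not separated from methoxy. In a physicochemical assay for solubility, at pH 7.4 (on this read-out lower numbers stand for lower solubility and higher numbers for higher solubility), compound 3 gives 257000 nM and compound 4 gives 94000 nM and the same change goes with a loss of solubility beyond the scatter: the measured solubility of compound 3, 257000 nM, and of compound 4, 94000 nM, a 2.7-fold lower number (0.44 log units; beyond the scatter)

The compounds shown leave open how a hydroxyl, a fluorine or an amine on this carbon would read in the A10 assay or in the physicochemical assay. They also leave open whether either methoxy that remains in compound 4 can be replaced by hydrogen with a similar result.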